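The source may report more compounds than this note shows. Statements on the series, on what has been measured and on what is new or still open speak of the compounds shown alone.

Compounds measured so far:

compound 1, `CC(C)n1cc(S(=O)(=O)c2ccc(CNC(=O)N3Cc4ccncc4C3)cc2)cn1`: 192000 nM
compound 2, `CN1CCC(S(=O)(=O)c2ccc(CNC(=O)N3Cc4ccncc4C3)cc2)CC1`: 240000 nM
compound 3, `O=C(NCc1ccc(S(=O)(=O)N2CCC[C@@H](O)C2)cc1)N1Cc2ccncc2C1`: 216000 nM

All three share one core and differ only in the group attached to the sulfonyl sulfur. In a physicochemical assay for solubility, in phosphate buffer, with a stated time of 24 h, at pH 7.4, tested at 100 uM (a higher number here means a more soluble compound, a lower number a less soluble compound), compound 1 gives the lowest of the three numbers, but its gap to each of the others is small: a 1.3-fold higher number from compound 1 to compound 2 (0.10 log units; within the scatter) and a 1.1-fold higher number from compound 1 to compound 3 (0.05 log units; within the scatter) both sit within the scatter, so the three compounds cannot be ordered on these data.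

Compound 4, `O=C(NCc1ccc(S(=O)(=O)N2CCC(N3CCCC3)CC2)cc1)N1Cc2ccncc2C1`, is not yet measured. Compared with compound 1 it carries 4-(pyrrolidin-1-yl)piperidin-1-yl in place of 1-isopropyl-1H-pyrazol-4-yl on a sulfonyl sulfur.

The two measured steps that bear on this change are the ones from compound 1 in which a saturated six-membered nitrogen ring took the place of the same pyrazole group on the sulfonyl sulfur; neither moved the number beyond the scatter. The change to compound 4 is of the same kind, so no step beyond the scatter is expected in this assay, in either direction. The step from compound 1 to compound 4 is estimated as a 1.1-fold higher number from compound 1 to compound 4 (0.06 log units; within the scatter). For compound 4 the expected value is 220000 nM, with a range from 120000 nM to 350000 nM.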

Compound 4, solubility: 6200 nM
For compound 4 the middle estimate is 35-fold (1.55 log units) above the measured one; the measured number lies below the stated range.
By their numbers in this assay, from the lowest: compound 4; then compounds 1, 3 and 2 (each within the scatter of the next).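

This result shows that the group on the sulfonyl sulfur is not a neutral position in this assay, since one change there gives a 31-fold lower number from compound 1 to compound 4 (1.49 log units; beyond the scatter). The two other steps are of similar size, a 35-fold lower number from compound 3 to compound 4 (1.54 log units; beyond the scatter) and a 39-fold lower number from compound 2 to compound 4 (1.59 log units; beyond the scatter), so a saturated six-membered nitrogen ring at this place does not by itself keep the number high: compounds 2 and 3 carry such a ring and stay high, while compound 4 does not. Nothing measured here explains the drop.

The compounds shown leave open whether the fall belongs to the pyrrolidine ring itself or would also appear with a simpler group, such as an unsubstituted piperidin-1-yl or a 4-(dimethylamino)piperidin-1-yl. A single compound also cannot show how general this fall is.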